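A Ring Swap at the Limit of the Assay

The compounds below may be only part of what the source reports. "The series", "measured", "known", "first", "only" and "open" are said of these compounds alone.

Measured in a functional assay on ECV-304 cells (Homo sapiens) for cytotoxicity; a higher number here means a weaker inhibitor, a lower number a stronger inhibitor:
Compound 1 `COc1ccc(S(=O)(=O)NN2C(=S)S/C(=C\c3ccc(Cl)c(Cl)c3)C2O)cc1`: > 50000 nM
Compound 2 `O=C1/C(=C/c2ccccc2F)SC(=S)N1NS(=O)(=O)c1ccccc1`: > 50000 nM

In this assay compound 2 gives only a limit, > 50000 nM, and not an exact number. Compound 1 is no different, so the whole picture so far is the limit of > 50000 nM in this assay, at which 2 of the 2 values shown sit. Compound 3 `O=C1/C(=C/c2ccc(Cl)c(F)c2)SC(=S)N1NS(=O)(=O)c1ccccc1` changes compound 2 in one place: 4-chloro-3-fluorophenyl in place of 2-fluorophenyl on a double-bonded chain carbon bound to a double-bonded ring carbon. Among the compounds with values here, no measured pair shows what such a swap does in this assay, so the expectation rests on that limit alone. A small shift towards a stronger inhibitor is expected, or none beyond the scatter. The estimated change is an at least 1.1-fold lower number from compound 2 to compound 3 (0.04 log units; that floor lies within the scatter). Compound 3 is expected to give about 45000 nM, within an estimated range from 15000 nM to 100000 nM.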

Compound 3, half-maximal inhibitory concentration: > 50000 nM
Compound 3 was reported as a limit; the forecaster's own chance of this, stated with the estimate: 65%; middle value at least 1.1-fold (0.04 log units) from the limit.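

Compound 2 and compound 3 both give only a limit, so the step between them cannot be read: the limit of > 50000 nM in this assay, at which 3 of the 3 values shown sit.

The compounds shown leave open what 4-chloro-3-fluorophenyl in place of 2-fluorophenyl does in this assay, and whether any close relative gives an exact number there.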